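The compounds below may be only part of what the source reports. "The series", "measured", "known", "first", "only" and "open" are said of these compounds alone.

Compound 1 `NCc1csc(NC(=O)c2cnn[nH]2)n1`: > 100 ug/mL
Compound 2 `CC(C)(C)c1cc(C(=O)Nc2ccncc2)n(Cc2ccccc2)n1`: 6.3 ug/mL

Among the measured compounds shown here, in a physicochemical assay for solubility, read by nephelometry, measured as kinetic solubility, at pH 6.5 (a higher number here means a more soluble compound, a lower number a less soluble compound), compound 2 gives 6.3 ug/mL, the only plain number among the two values shown. Compound 1 gives > 100 ug/mL, which is a limit of the assay rather than a number, namely (the limit of > 100 ug/mL in this assay, at which 1 of the 2 values shown sits). Compound 3 `CC(C)(C)c1cc(C(=O)Nc2cccnc2)n(Cc2ccccc2)n1` differs from compound 2 by pyridin-3-yl in place of pyridin-4-yl on an amide-type nitrogen. For the measured compounds named here, no measured pair showing a change of this kind exists here, so the expectation rests on compound 2 alone, and the step of a 1.3-fold higher number from compound 2 to compound 3 (0.10 log units; within the scatter) is expected to stay within the usual scatter. Compound 3 is therefore estimated at 8 ug/mL, with a range from 3 ug/mL to 25 ug/mL.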

Compound 3, solubility: 6.3 ug/mL
Compound 3: the middle estimate sits 1.3-fold (0.10 log units) above what was measured, and the stated range covers the measured number.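

In this assay, pyridin-3-yl in place of pyridin-4-yl on an amide-type nitrogen gives no change at the digits printed from compound 2 to compound 3 (within the scatter). This is the first pair shown that differs in one place, and at this position the two groups, with the same atoms joined differently, cannot be told apart by this read-out. Nothing in the evidence shown bears on this result. As far as these compounds go, whether pyridin-2-yl or a phenyl at this place would read the same remains open. So does the effect of an amine or a carboxylic acid on the pyridine ring.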